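Replacing a Chlorophenylethenyl Group with Furanyl

This account rests on a few compounds, and the source may have more. Where it says the series, first, only, none or still open, it means among the compounds named here.

Measured compounds:
- compound 1, `CC(C)(C)Cc1c(/C=C/c2ccc(Cl)cc2)sc(N)c1C(=O)c1ccc(Cl)cc1`: 11%
- compound 2, `Cc1ccc(C(=O)c2c(CC(C)(C)C)csc2N)cc1`: 1%

Both measurements come from an assay on CHO cells for displacement of a labelled ligand from adenosine receptor A3 (Homo sapiens), read by scintillation counting, tested at 10 uM; on this read-out lower numbers stand for less inhibition and higher numbers for more inhibition at the one concentration tested (going by the name of the read-out). In this assay compound 1 gives 11%, and compound 2 gives 1%; the two numbers lie within the usual scatter of each other, so neither stands apart. Both are small, meaning little displacement at the one concentration tested.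

Compound 3, `CC(C)(C)Cc1c(-c2ccco2)sc(N)c1C(=O)c1ccc(Cl)cc1`, has not been measured. It differs from compound 1 in one place: furan-2-yl in place of 2-(4-chlorophenyl)ethenyl on an aromatic carbon. Going by the values given here, no step between measured compounds that differ in one place is known here, so there is nothing to lean on beyond the two small values.

Given that compound 1 gives 11% and compound 2 gives 1%, compound 3 is expected to stay in the same low region. The step of a number 3 percentage points lower from compound 1 to compound 3 (within the scatter) is expected to be small and within the scatter. The estimate for compound 3 is 8%, with a range from 0% to 25%.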

Compound 3, a percentage reported as inhibition, at one concentration (the size of the read-out at that concentration, not a potency): 1%
Compound 3: middle estimate off by 7 percentage points, on the high side, within the range that was stated.
By their numbers in this assay, from the lowest: compounds 2, 3 and 1 (each within the scatter of the next).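

Going by these compounds alone, this is the first step in the set that changes only one place: the aromatic carbon next to the ring sulfur. In this assay, putting furan-2-yl in place of 2-(4-chlorophenyl)ethenyl gives a number 10 percentage points lower from compound 1 to compound 3 (within the scatter), so this exchange of a group of 9 heavy atoms for one of 5 does not move the result beyond the usual scatter. Nothing measured here offers an explanation for this outcome.

On these data alone, with so little displacement at the single concentration tested, it remains open whether a different kind of group on this carbon, such as an amine or a carboxylic acid, would give a clearly higher number. Also open, as far as these compounds go, is whether a longer chain in place of the neopentyl group would change the result for the core of compound 3.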